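The compounds below may be only part of what the source reports. "The series", "measured", "known", "first", "only" and "open" are said of these compounds alone.

Of the compounds shown here, three built on a shared core have been measured in a physicochemical assay for solubility, read by LC-MS, in phosphate buffer, measured as kinetic solubility, with a stated time of 24 h, at 25 degrees C, at pH 7.4; on this read-out higher numbers stand for higher solubility and lower numbers for lower solubility. Compound 1 `Nc1cc(-c2ccc3c(N)n[nH]c3c2)nc(N)n1` gives 58000 nM in that read-out. Compound 2 `Nc1nccc(-c2ccc3c(NCc4ccccc4)n[nH]c3c2)n1` gives 17000 nM. Compound 3 `Nc1nccc(-c2cc(OCc3ccccc3)c3c(N)n[nH]c3c2)n1` gives 85000 nM. Among these three numbers, compound 3 holds the highest one. Its value and that of compound 1, however, sit within the usual scatter of each other, so no order between those two can be read from the data. The gap from compound 3 to compound 2 is beyond that scatter, with compound 2 showing the lower number.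

Compound 4 `Nc1nccc(-c2cc(OC3COC3)c3c(N)n[nH]c3c2)n1` has not yet been measured in this assay. It differs from compound 3 in a single place: oxetan-3-yl in place of benzyl on an oxygen on an aromatic ring. Among the compounds with values here, no pair among the measured compounds differs in exactly this way, so there is no measured step that shows what this change does, and any expectation has to be framed against compound 3 alone.

The step from compound 3 to compound 4 in this assay is expected to be a 1.9-fold higher number from compound 3 to compound 4 (0.27 log units; within the scatter), an upward move somewhat beyond the scatter. On that basis compound 4 is expected to give about 160000 nM, with a plausible range from 60000 nM to 400000 nM.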

Compound 4, solubility: 383000 nM
The estimate for compound 4 lay 2.4-fold (0.38 log units) below the measured number; low and high end bracket the measured number.
By their numbers in this assay, from the lowest: compound 2; then compounds 1 and 3 (each within the scatter of the next); then compound 4.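

In this assay, within the data shown here, putting oxetan-3-yl in place of benzyl on an oxygen on an aromatic ring gives a 4.5-fold higher number from compound 3 to compound 4 (0.65 log units; beyond the scatter) as the first measured step at this place. Before this result, compound 3 was the only measured compound with a group on this oxygen, so nothing could show whether the read-out would respond to a change of that group. Compounds 3 and 4 differ in this one place only, and the step lies beyond the usual scatter, so the number does move with the group here, and in the upward direction for this particular swap.

This single pair changes several things at once: the six-membered aromatic ring of carbon leaves, the group becomes smaller in heavy atoms, and a four-membered ring with a hydrogen-bond acceptor enters, so methyl, cyclobutyl or a short chain carrying an amine on the same oxygen would be needed to begin separating these differences. The data shown offer no measured reason for the size or direction of this step.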